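Adding a Second Chlorine to a Phenylurea Series

This account rests on a few compounds, and the source may have more. Where it says the series, first, only, none or still open, it means among the compounds named here.

Compound 1, `C[C@@H](NC(=O)Nc1ccccc1Cl)c1ccccc1`, and compound 3, `C[C@@H](NC(=O)Nc1ccc(Cl)cc1Cl)c1ccccc1`, share one core, and compound 3 carries one chlorine more. In an ADME assay on the whole organism with Oryza sativa as the target, tested at 10 uM (a higher number here means a weaker effect of the compound at the concentration tested, a lower number a stronger effect), compound 1 gives 93%, while compound 3 gives 100%. The change between them, (chloro in place of hydrogen on an aromatic carbon), made a number 7 percentage points higher from compound 1 to compound 3 (within the scatter). Compound 2, `C[C@@H](NC(=O)Nc1cccc(Cl)c1)c1ccccc1`, has the same atoms as compound 1 joined differently; how the two cores differ is not broken down here. In this assay compound 2 gives 83%. Its value and that of compound 1 lie within the usual scatter of each other, whereas compound 3 stands beyond the scatter from compound 2.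

Compound 4, `C[C@@H](NC(=O)Nc1cc(Cl)cc(Cl)c1)c1ccccc1`, is not yet measured. It arises from compound 2 by the same kind of change: chloro in place of hydrogen on an aromatic carbon. The surroundings differ in one respect: in compound 4 the entering chloro is meta to a large group, while in compound 3 it is para to a large group. A step of a number 7 percentage points higher from compound 2 to compound 4 (within the scatter) is expected in this assay because a number 7 percentage points higher from compound 1 to compound 3 (within the scatter). Compound 4 is thus expected to give about 90%, most likely between 76% and 100%.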

Compound 4, a percentage reported as activity, at one concentration (the size of the read-out at that concentration, not a potency): 99%
Estimate against measurement, compound 4: 9 percentage points below; low and high end bracket the measured number.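

In this assay, swapping a hydrogen on the aromatic ring for a chloro once more gives a number 16 percentage points higher from compound 2 to compound 4 (beyond the scatter), so this step, unlike the earlier one, stands clear of the usual noise in the measurement. Even so, the two steps point the same way, and the gap between them is too small to count as a real difference between the two cores: the same change on two cores in this assay, a number 7 percentage points higher (within the scatter) from compound 1 to compound 3 and a number 16 percentage points higher (beyond the scatter) from compound 2 to compound 4, 9 percentage points apart, within the scatter of two such steps. This shows that the change carried over from one core to the other about as well as can be judged here, but two pairs make no general rule, and because the entering chloro sits in a different place in each pair, they cannot separate any influence of that place from that of the core.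

From the compounds shown here alone, it remains open whether a bromine, a methoxy group or a carboxylic acid entering at the same place would give a step of similar size. Going by these compounds, it also remains open whether the chloro step would hold on any core beyond these two.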